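Methyl in place of ethoxy on the shared core

The compounds below may be only part of what the source reports. "The series", "measured", "known", "first", "only" and "open" are said of these compounds alone.

Measured compounds:
compound 1, `CCOc1ccc(NC2=CC(=O)c3ncncc3C2=O)cc1`: 0.02 ug/mL
compound 2, `O=C1C(Nc2ccc(Br)cc2)=CC(=O)c2ncncc21`: 0.02 ug/mL

In a functional assay on SK-MEL-2 cells (Homo sapiens) for cytotoxicity, read by MTT assay, with a stated time of 72 h (a lower number here means a stronger inhibitor, a higher number a weaker inhibitor), compound 1 gives 0.02 ug/mL and compound 2 gives 0.02 ug/mL, so compound 1 stands level with compound 2 at the digits shown, the two values lying within the scatter of each other. For the measured compounds named here, the single measured step, no change at the digits printed from compound 1 to compound 2 (within the scatter), brings no change within the scatter.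

Compound 3, `Cc1ccc(NC2=CC(=O)c3ncncc3C2=O)cc1`, differs from compound 1 by methyl in place of ethoxy on an aromatic carbon. Going by the values given here, no measured step involves a methyl group, so the expectation rests only on the one step available: exchanging the ethoxy of compound 1 for bromo left the value unchanged, and a second exchange on the same aromatic carbon is expected to behave alike. The expected step is no change at the digits printed from compound 1 to compound 3 (within the scatter), that is, none beyond the scatter. Compound 3 is therefore estimated at 0.02 ug/mL, within a range of 0.01 ug/mL to 0.05 ug/mL.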

Compound 3, half-maximal inhibitory concentration: 0.02 ug/mL
The estimate for compound 3 equals the measured number at the digits printed; the range from low to high includes it.
By their numbers in this assay, from the lowest: compounds 1, 2 and 3 (each within the scatter of the next).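

In this assay the exchange of ethoxy for methyl on this aromatic carbon, para to a large group, gives no change at the digits printed from compound 1 to compound 3 (within the scatter), and the exchange of bromo for methyl gives no change at the digits printed from compound 2 to compound 3 (within the scatter). Earlier, only ethoxy and bromo had been compared here; methyl adds a smaller group with no hydrogen-bond acceptor, and the values still do not separate, so across these three compounds neither the size of the group nor the loss of the ethoxy acceptor is tied to any difference. No measurement shown bears on the reason for this.

Still open, as far as these compounds go, is whether an amine, a carboxylic acid or a longer alkyl chain at this carbon would also stay level with these three compounds. The compounds shown also leave open what a ring with only hydrogen at this carbon would give.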